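This account rests on a few compounds, and the source may have more. Where it says the series, first, only, none or still open, it means among the compounds named here.

Compound 1 `N#Cc1ccc(Nc2nccc(OCc3cccnc3)n2)cc1` and compound 2 `N#Cc1ccc(Nc2nccc(OCc3cccc(Br)c3)n2)cc1` share a core and differ only at the saturated chain carbon bound to an oxygen on an aromatic ring. Within the data shown here, in an ADME assay on MT4 cells (Homo sapiens) for cytotoxicity, read by MTT assay, with a stated time of 5 days (on this read-out higher numbers stand for lower toxicity in this test and lower numbers for higher toxicity in this test), compound 1 gives 6400 nM, the lower of the two numbers, while compound 2 gives 221000 nM; the single step of a 35-fold higher number from compound 1 to compound 2 (1.54 log units; beyond the scatter) is large. Compound 3 `Cc1ccccc1COc1ccnc(Nc2ccc(C#N)cc2)n1` carries the change (2-methylphenyl in place of pyridin-3-yl on a saturated chain carbon bound to an oxygen on an aromatic ring). Among the measured compounds shown here, only that one step bears on it, and it again trades pyridin-3-yl for a carbon-only ring, so a rise is expected, as a 9.4-fold higher number from compound 1 to compound 3 (0.97 log units; beyond the scatter). Compound 3 is therefore estimated at 60000 nM, within 15000 nM to 250000 nM.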

Compound 3, half-maximal cytotoxic concentration: 12000 nM
Compound 3: middle estimate off by 5.0-fold (0.70 log units), on the high side; the measured number lies below the stated range.
By their numbers in this assay, from the lowest: compounds 1 and 3 (each within the scatter of the next); then compound 2.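

In this assay, a carbon-only ring in place of pyridin-3-yl does not by itself shift the number: a 1.9-fold higher number from compound 1 to compound 3 (0.27 log units; within the scatter) leaves compound 1 and compound 3 within the scatter of each other. The large gap therefore belongs to 3-bromophenyl and not to carbon-only rings in general, as an 18-fold lower number from compound 2 to compound 3 (1.27 log units; beyond the scatter) shows. No supporting measurement accounts for this difference. Still open, from the compounds shown here alone, is whether 3-methylphenyl or 2-bromophenyl would follow compound 3 or compound 2. Going by these compounds, how an amine or a carboxylic acid on this ring would read also remains open.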